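Replacing a thiazoline by an oxazoline on the sulfonylmethyl arm

The source may hold more compounds than are shown below. What is called first, only, known or untested is meant among the compounds shown, and "the series" means these compounds.

Measured compounds:
- compound 1, `COc1ccc(-c2nn(-c3ccccc3)c(-c3ccc(C)cc3)c2S(=O)(=O)CC2=NCCS2)cc1`: "not active" (no number reported)
- compound 2, `Cc1ccc(C2CNN=C2S(=O)(=O)CC2=NCCS2)cc1`: 42.2%

Two compounds carry a measurement in a functional assay, tested at 75 ug/mL; on this read-out higher numbers stand for a stronger effect at the one concentration tested and lower numbers for a weaker effect. Compound 1, `COc1ccc(-c2nn(-c3ccccc3)c(-c3ccc(C)cc3)c2S(=O)(=O)CC2=NCCS2)cc1`, is recorded in this assay as "not active" (no number reported), with no number attached to it, so its standing cannot be placed on the scale. Within the data shown here, compound 2, `Cc1ccc(C2CNN=C2S(=O)(=O)CC2=NCCS2)cc1`, gives 42.2%; it shares the sulfonylmethyl-thiazoline arm with compound 1 but differs from it in much of the rest, and no step between them is defined.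

Compound 3, `COc1ccc(-c2nn(-c3ccccc3)c(-c3ccc(C)cc3)c2S(=O)(=O)CC2=NCCO2)cc1`, keeps the whole frame of compound 1 and changes only one part: a group of 5 heavy atoms (3 carbon, 1 nitrogen, 1 oxygen; one five-membered non-aromatic ring with 2 hetero atoms) in place of a group of 5 heavy atoms (3 carbon, 1 nitrogen, 1 sulfur; one five-membered non-aromatic ring with 2 hetero atoms), on a saturated chain carbon bound to a sulfonyl sulfur. Among the measured compounds shown here, with compound 1 reported only as inactive and no measured pair showing what this exchange does, there is no basis for expecting a move of a particular size in this assay in either direction, and an outcome close to that of compound 1, within the scatter, is the plainest reading. Compound 3 is therefore estimated in this assay at 12%, with a range from 0% to 40%.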

Compound 3, a percentage reported as activity, at one concentration (the size of the read-out at that concentration, not a potency): 68.7%
Compound 3: middle estimate off by 56.7 percentage points, on the low side; measured number above the stated range.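

Among these compounds, no step from compound 1 to compound 3 can be read: compound 1 stands as "not active" (no number reported) in this assay, without a number, while compound 3 gives 68.7%. Nothing measured here bears on the cause of this result. The compounds shown leave open how large an effect the exchange of thiazoline for oxazoline has.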